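This account rests on a few compounds, and the source may have more. Where it says the series, first, only, none or still open, it means among the compounds named here.

Measured compounds:
compound 1 `CCn1c(SCC(=O)Nc2ccc(/C(C)=N/O)cc2)nnc1-c1ccc(OC)c(OC)c1`: 73%
compound 2 `COc1ccc(-c2nnc(SCC(=O)Nc3ccc(/C(C)=N/O)cc3)n2-c2ccccc2)cc1`: 58%

In a functional assay on the whole organism (strain albino) for inhibition, with Rattus norvegicus as the target, read by paw edema, with stated times of 30 min and 5 h, at a dose of 0.28 mmol/kg by the oral route (a higher number here means more inhibition at the dose given (going by the name of the read-out), a lower number less inhibition), compound 1 gives 73% and compound 2 gives 58%. Compound 2 stands lowest of the two numbers; its nearest neighbour, compound 1, lies higher by a gap beyond the usual scatter of this assay. Compound 3 `CCn1c(SCC(=O)Nc2ccc(/C(C)=N/O)cc2)nnc1-c1ccc(OC)cc1` differs from compound 2 by ethyl in place of phenyl on an aromatic nitrogen. Among the compounds with values here, no measured pair shows this single change on its own, since compound 1 also carries an ethyl on that nitrogen but differs from compound 3 in another part of the structure as well, so its higher number cannot be credited to the ethyl alone. Within the data shown here, still, the only ethyl-bearing compound measured, compound 1 at 73%, lies above compound 2, and a number 8 percentage points higher from compound 2 to compound 3 (within the scatter) is therefore expected to be an increase of modest size rather than none. Compound 3 is expected to give about 66%, within 54% to 78%.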

Compound 3, a percentage reported as inhibition, in the whole organism at one dose (the size of the read-out at that dose, not a potency): 65%
Beside the measured number, compound 3's estimate is 1 percentage points above it, and the stated range covers the measured number.
By their numbers in this assay, from the lowest: compounds 2, 3 and 1 (each within the scatter of the next, the first and the last beyond it).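

In this assay, the exchange on the aromatic nitrogen of the five-membered ring can now be read on its own: ethyl in place of phenyl gives a number 7 percentage points higher from compound 2 to compound 3 (within the scatter), so this read-out does not separate the two groups at this position. Within the data shown here, the methoxy on the aromatic carbon can also be read alone for the first time, and hydrogen in its place gives a number 8 percentage points lower from compound 1 to compound 3 (within the scatter). Neither single change, taken by itself, lies beyond the scatter. Nothing available bears on the reason for these steps.

Still open, on these data alone, is whether another group on that nitrogen, such as a longer chain like butyl or a benzyl, would give a step beyond the scatter. As far as these compounds go, it is also open how an amine or a chlorine in place of that methoxy would read.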